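Adding a Second Trifluoromethyl Group to Compound 2

This account rests on a few compounds, and the source may have more. Where it says the series, first, only, none or still open, it means among the compounds named here.

Compound 2 `Cc1cc(C(=O)O)nn1Cc1cc(Br)ccc1OCc1cccc(C(F)(F)F)c1` was examined in a functional assay on CHO-K1 cells for antagonist activity at prostaglandin E2 receptor EP1 subtype (Homo sapiens), read by FLIPR (on this read-out lower numbers stand for stronger inhibition and higher numbers for weaker inhibition), where compound 2 gives 1100 nM. Going by the values given here, of the two values measured so far this is the higher one; its nearest neighbour, compound 1 `Cc1cc(C(=O)O)nn1Cc1cc(Br)ccc1OCc1ccccc1`, gives 15.1 nM in this assay. Among the compounds with values here, the one measured step, a 73-fold higher number from compound 1 to compound 2 (1.86 log units; beyond the scatter), is the only one that bears on the change now at hand: trifluoromethyl in place of hydrogen on an aromatic carbon, the new group sitting meta to the trifluoromethyl group already present, which yields compound 3 `Cc1cc(C(=O)O)nn1Cc1cc(Br)ccc1OCc1cc(C(F)(F)F)cc(C(F)(F)F)c1`. Because the first trifluoromethyl already brought a 73-fold higher number from compound 1 to compound 2 (1.86 log units; beyond the scatter), a second one is expected to push the number further in the same direction, though it need not be by as much. Compound 3 is therefore expected to show a 3.2-fold higher number from compound 2 to compound 3 (0.50 log units; beyond the scatter) in this assay. The estimate for compound 3 is 3500 nM, with a likely range from 900 nM to 14000 nM.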

Compound 3, inhibition constant: < 2000 nM
Compound 3: a limit, no number; the forecaster's own chance of this, stated with the estimate: 20%; middle value at least 1.7-fold (0.24 log units) from the limit.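

In this assay compound 3 gives < 2000 nM, which is a limit and not a number. The step from compound 2 to compound 3 therefore cannot be read. The compounds shown leave open whether the second trifluoromethyl group changes the number at all, and in which direction.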